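The source may report more compounds than this note shows. Statements on the series, on what has been measured and on what is new or still open speak of the compounds shown alone.

In an ADME assay (Rattus norvegicus, strain Han-wistar) for metabolic stability, at a dose of 1.5 umol/kg by the intravenous route (on this read-out higher numbers stand for a longer-lived compound and lower numbers for a shorter-lived compound), compound 3 (`CC(C)n1nc(-c2ccnc3[nH]c(C4CCN(CC(=O)N(C)C)CC4)cc23)ccc1=O`) gives 1 h, level with compound 2 (`COc1cc(F)ccc1-c1ccnc2[nH]c(C3CCN(CC(=O)N(C)C)CC3)cc12`), which gives 1 h. Compound 1 (`CC(C)n1cc(-c2ccnc3[nH]c(C4CCN(CC(=O)N5CCCC5)CC4)cc23)ccc1=O`) gives 1.1 h, within the scatter of both, so the three values do not separate.

Compound 4 (`CC(C)n1cc(-c2ccnc3[nH]c(C4CCN(CC(=O)N(C)C)CC4)cc23)cnc1=O`) differs from compound 3 in one place: a group of 10 heavy atoms (7 carbon, 2 nitrogen, 1 oxygen; one six-membered aromatic ring with 2 hetero atoms) in place of a group of 10 heavy atoms (7 carbon, 2 nitrogen, 1 oxygen; one six-membered aromatic ring with 2 hetero atoms), on an aromatic carbon. The two have the same atoms, joined differently, and the group sits on an aromatic carbon of the shared core, opposite the ring nitrogen.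

Going by the values given here, the one measured step that bears on this change is no change at the digits printed from compound 2 to compound 3 (within the scatter), an exchange of groups on that same aromatic carbon. Among the compounds with values here, no measured step yet isolates the present rearrangement of the ring, so the evidence is indirect and thin. Within the data shown here, with only that step to go on, no shift beyond the scatter is expected in this assay, and the direction is left open. The expected step is no change at the digits printed from compound 3 to compound 4 (within the scatter). For compound 4 the estimate is 1 h, with an expected range from 0.6 h to 1.7 h.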

Compound 4, half-life: 1 h
Estimate against measurement, compound 4: no gap at the digits printed; low and high end bracket the measured number.
By their numbers in this assay, from the lowest: compounds 2, 3, 4 and 1 (each within the scatter of the next).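

Moving the ring atoms of the group on the aromatic carbon opposite the ring nitrogen, with its atom count unchanged, gives in this assay no change at the digits printed from compound 3 to compound 4 (within the scatter) and so adds a direct measurement of this rearrangement. Replacing the ring of carbon only with the group of compound 4 gives no change at the digits printed from compound 2 to compound 4 (within the scatter) and so matches the earlier exchange at this position: neither ring with 2 hetero atoms separates from the ring of carbon only. Nothing available explains why these groups do not separate.

From the compounds shown here alone, whether a carboxylic acid or a primary amine on this aromatic ring would shift the half-life beyond the scatter remains open. The amide is also unresolved, since compound 1 differs from these compounds in more than one place, and a morpholine amide is not among those shown.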